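Shortening the triazole substituent in a chromanone series

A few compounds are considered here, and "the series" means these few. Any claim that something is new, unique, unknown or untested is made for them only; others in the source may bear on it.

Measured compounds:
compound 1 `CCn1cc(COc2cc(O)c3c(c2)O[C@H](c2ccc(OC)c(O)c2)C/C3=N\O)nn1` gives 3140 nM
compound 2 `COc1ccc([C@@H]2CC(=O)c3c(O)cc(OCc4cn(Cc5ccccc5C(F)(F)F)nn4)cc3O2)cc1O` gives 12500 nM
compound 3 `CCCCn1cc(COc2cc(O)c3c(c2)O[C@H](c2ccc(OC)c(O)c2)C/C3=N\O)nn1` gives 8900 nM

Of the compounds shown here, three share a core and have been tested in a functional assay on RAW264.7 cells (Mus musculus) for inhibition, read by Griess assay, with stated times of 2 h and 24 h; on this read-out lower numbers stand for stronger inhibition and higher numbers for weaker inhibition. Compound 2 stands highest of the three numbers; its gap to compound 3 lies within the scatter, while its gap to compound 1 lies beyond it. The unmeasured compound 4 `COc1ccc([C@@H]2CC(=O)c3c(O)cc(OCc4cn(C)nn4)cc3O2)cc1O` differs from compound 2 in one place: hydrogen in place of 2-(trifluoromethyl)phenyl on a saturated chain carbon bound to an aromatic nitrogen.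

Among the measured compounds shown here, the only measured step that bears on this change runs along the same triazole substituent: a 2.8-fold higher number from compound 1 to compound 3 (0.45 log units; beyond the scatter). There the longer chain gave the higher number, so a shorter group on the saturated chain carbon bound to the aromatic nitrogen might be expected to lower the number. Compounds 1 and 3 carry an oxime where compounds 2 and 4 carry a carbonyl, so the analogy is loose, and the group removed here is larger than the chain added there.

Compound 4 is therefore expected to give a modestly lower number, 6000 nM (range 2500 nM to 15000 nM), an estimated step of a 2.1-fold lower number from compound 2 to compound 4 (0.32 log units; beyond the scatter).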

Compound 4, half-maximal inhibitory concentration: 15200 nM
The estimate for compound 4 lay 2.5-fold (0.40 log units) below the measured number; measured number outside the range, above it.
By their numbers in this assay, from the lowest: compound 1; then compounds 3, 2 and 4 (each within the scatter of the next).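

In this assay the change from 2-(trifluoromethyl)benzyl to methyl in the carbonyl compounds produced a 1.2-fold higher number from compound 2 to compound 4 (0.08 log units; within the scatter) and so gave no separation between the two, even though an entire aromatic ring left this saturated chain carbon bound to an aromatic nitrogen. In the oxime pair, by contrast, the chain change gave a 2.8-fold higher number from compound 1 to compound 3 (0.45 log units; beyond the scatter) which lies beyond the scatter, so the link seen there between a shorter substituent and a lower number did not appear in this carbonyl pair. Nothing measured here accounts for that difference.

The compounds shown leave open whether an oxime and a carbonyl carrying the same triazole substituent would give matching numbers. They also leave open whether an amine or a carboxylic acid in place of 2-(trifluoromethyl)phenyl would shift the number beyond the scatter.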